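This account rests on a few compounds, and the source may have more. Where it says the series, first, only, none or still open, it means among the compounds named here.

Measured compounds:
- compound 1, `Cc1ccccc1-c1cc(C#Cc2ccc(CCC(=O)O)cc2)ccn1`, 1070 nM
- compound 2, `O=C(O)CCc1ccc(C#Cc2ncccc2[N+](=O)[O-])cc1`, 11000 nM
- compound 3, `O=C(O)CCc1ccc(C#Cc2cccs2)cc1`, 251 nM

Three compounds were tested in an in vitro functional assay on 1321-N1 cells for agonist activity at Free fatty acid receptor 1 (Homo sapiens), read by fluorescence, spectrophotometry and calcium flux; on this read-out higher numbers stand for an effect only at larger amounts of compound and lower numbers for an effect already at smaller amounts. Compound 1 stands second highest of the three numbers: compound 3 gives the nearest number, 251 nM, lower by a gap that is beyond the usual scatter, while compound 2 gives the furthest, 11000 nM, higher by a gap that is also beyond the scatter. Compound 1 itself gives 1070 nM in this assay.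

The next compound, compound 4, `O=C(O)CCc1ccc(C#Cc2ccnc(Cl)c2)cc1`, has not yet been measured. It differs from compound 1 in one place: chloro in place of 2-methylphenyl on an aromatic carbon. The chloro sits on an aromatic carbon of a six-membered aromatic ring with one nitrogen, next to the ring nitrogen and meta to a large group. For the measured compounds named here, no pair of measured compounds differing in a single place is available, so nothing is known directly about what such a change does in this assay.

The expectation rests only on the three numbers shown. Because compound 2, which also carries a small group on the six-membered ring with one nitrogen, gives 11000 nM, a step toward a higher number is expected, of a size estimated at a 2.3-fold higher number from compound 1 to compound 4 (0.37 log units; beyond the scatter), beyond the scatter but well short of the gap to compound 2. Compound 4 is therefore expected to give about 2500 nM in this assay, within a range from 600 nM to 10000 nM.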

Compound 4, half-maximal effective concentration: 295 nM
Compound 4: middle estimate off by 8.5-fold (0.93 log units), on the high side; the whole stated range lies above it.
By their numbers in this assay, from the lowest: compounds 3 and 4 (each within the scatter of the next); then compound 1; then compound 2.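

In this assay, for the compounds shown here, putting chloro in place of 2-methylphenyl, on an aromatic carbon next to the ring nitrogen and meta to a large group, gives a 3.6-fold lower number from compound 1 to compound 4 (0.56 log units; beyond the scatter) as the first single-place change that can be read in this set, and the step lies beyond the scatter. It shows that this position does not depend on the 2-methylphenyl to keep an effect in this assay: one chlorine atom stands in for seven carbon atoms and a whole ring, and the number falls rather than rises. The direction is the useful finding, as a far smaller group at this place is at least compatible with an effect at smaller amounts of compound than compound 1 needs.

The compounds shown leave open whether the chloro itself matters or only the loss of the 2-methylphenyl, and whether a plain phenyl, a methyl, a methoxy or an amine at the same place would side with compound 4 or with compound 1. Nothing measured on these compounds speaks to why the number moves in this direction.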